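Swapping the Methylamino Group of Compound 3 for Dimethylpiperidine

The source may hold more compounds than are shown below. What is called first, only, known or untested is meant among the compounds shown, and "the series" means these compounds.

Compound 1 `CC1=NN(C(=O)CN2CCN(C(=O)OC(C)(C)C)CC2)C(c2ccccc2O)C1` gives 3440 nM in a functional assay on PC-3 cells (Homo sapiens) for cytotoxicity, read by MTT assay, with a stated time of 48 h; on this read-out lower numbers stand for stronger inhibition and higher numbers for weaker inhibition. Compound 2 `CC1=NN(C(=O)CN2CCN(C)CC2)C(c2ccccc2O)C1` gives 11800 nM. Compound 3 `CNCC(=O)N1N=C(c2cc3ccccc3oc2=O)CC1c1ccccc1` gives 2300 nM.

Compound 3 has the lowest number of the three; its gap to compound 1 lies within the scatter, while compound 2 sits beyond it. Compound 4 `CC1CC(C)CN(CC(=O)N2N=C(c3cc4ccccc4oc3=O)CC2c2ccccc2)C1` differs from compound 3 by 3,5-dimethylpiperidin-1-yl in place of methylamino on a saturated chain carbon bound to a carbonyl carbon. Within the data shown here, the only measured step, a 3.4-fold higher number from compound 1 to compound 2 (0.54 log units; beyond the scatter), concerns a different exchange on an amine nitrogen in a ring, so it gives no direct guide. Among the measured compounds shown here, with a single modest step and no matching precedent, compound 4 is expected to change by a 1.1-fold higher number from compound 3 to compound 4 (0.04 log units; within the scatter), a step not clearly beyond the scatter in either direction. Compound 4 is therefore estimated at 2500 nM, within 800 nM to 8000 nM.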

Compound 4, half-maximal inhibitory concentration: "not active" (no number reported)
Compound 4 has no reported number here; no gap can be computed for the estimate.
By their numbers in this assay, from the lowest: compounds 3 and 1 (each within the scatter of the next); then compound 2.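

Among these compounds, compound 4 is reported as not active, with no number, and no step from compound 3 to compound 4 can be read. The compounds shown leave open how far the 3,5-dimethylpiperidin-1-yl exchange moves the read-out. No measured evidence bears on this result.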